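Swapping a chlorothiophene for a dichlorophenyl on an isoxazole

The source may report more compounds than this note shows. Statements on the series, on what has been measured and on what is new or still open speak of the compounds shown alone.

Of the compounds shown here, two with a shared core have been measured in an assay on isolated protein for positive allosteric modulation of Neuronal acetylcholine receptor; alpha4/beta2 (Homo sapiens); on this read-out higher numbers stand for an effect only at larger amounts of compound and lower numbers for an effect already at smaller amounts. Compound 1 `Fc1cccc(Cl)c1-c1cc(-c2cnn(C3CCNCC3)c2)on1` gives 48 nM in this assay, and compound 2 `Clc1sccc1-c1cc(-c2cnn(C3CCNCC3)c2)on1` gives 130 nM. Compound 2 thus stands at the higher of the two numbers, with a 2.7-fold higher number from compound 1 to compound 2 (0.43 log units; beyond the scatter) separating it from compound 1. Compound 3 `Clc1cccc(Cl)c1-c1cc(-c2cnn(C3CCNCC3)c2)on1` has not been measured; it differs from compound 2 by 2,6-dichlorophenyl in place of 2-chlorothiophen-3-yl on an aromatic carbon. Within the data shown here, the only step that bears on this change is the one from compound 1 to compound 2, where a 2-chlorothiophen-3-yl replaced a halogenated phenyl, and compound 3 returns to a halogenated phenyl that resembles compound 1 closely. A step of roughly the same size in the opposite direction is therefore expected, namely a 2.6-fold lower number from compound 2 to compound 3 (0.41 log units; beyond the scatter). Compound 3 is estimated at 50 nM in this assay, with a range from 20 nM to 125 nM.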

Compound 3, half-maximal effective concentration: 410 nM
For compound 3 the middle estimate is 8.2-fold (0.91 log units) below the measured one, and the stated range ends below it.
By their numbers in this assay, from the lowest: compound 1; then compound 2; then compound 3.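

Among these compounds, the second halogen on the phenyl ring matters far more here than the earlier compounds could suggest: chloro in place of fluoro gives an 8.5-fold higher number from compound 1 to compound 3 (0.93 log units; beyond the scatter). The 2-chlorothiophen-3-yl group therefore falls between the two phenyl groups, and with 2,6-dichlorophenyl in its place the result is a 3.2-fold higher number from compound 2 to compound 3 (0.50 log units; beyond the scatter), the opposite direction to the step from the fluorinated phenyl. So the effect of exchanging the thiophene for a phenyl ring at this position depends on which halogens that phenyl carries, and nothing available here explains this.

Going by these compounds, whether the number keeps falling with two fluoro groups, as in 2,6-difluorophenyl, remains open. So does the result for a plain phenyl ring without halogen, or for a methyl group in place of the chloro on the thiophene.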